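Swapping the Sulfonamide Cap on a Quinoline Sulfonamide

The compounds below may be only part of what the source reports. "The series", "measured", "known", "first", "only" and "open" are said of these compounds alone.

Of the compounds shown here, two share a core and have been tested in a functional assay on AS49-RAW cells (Homo sapiens) for antiproliferative activity, read by sulforhodamine B assay, with a stated time of 48 h; a lower number here means a stronger inhibitor, a higher number a weaker inhibitor. Compound 1 `O=C(Nc1ccccc1)Nc1ccc(S(=O)(=O)Nc2ccnc3cc(C(F)(F)F)ccc23)cc1` gives 24500 nM. Compound 2 `CC(=O)NS(=O)(=O)c1ccc(N/C(S)=N\c2ccnc3cc(C(F)(F)F)ccc23)cc1` gives 37600 nM; the two numbers lie within the usual scatter of each other, so neither stands apart. Compound 3 `Cc1noc(NS(=O)(=O)c2ccc(N/C(S)=N\c3ccnc4cc(C(F)(F)F)ccc34)cc2)c1C` is not yet measured. It differs from compound 2 in one place: 3,4-dimethyl-1,2-oxazol-5-yl in place of acetyl on a sulfonamide nitrogen. Within the data shown here, no measured pair shows this change, so the step from compound 2 to compound 3 is expected to stay small, a 1.7-fold lower number from compound 2 to compound 3 (0.23 log units; within the scatter), most likely within the scatter. Compound 3 is therefore estimated at 22000 nM, with a range from 6000 nM to 70000 nM.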

Compound 3, half-maximal inhibitory concentration: 34000 nM
The estimate for compound 3 lay 1.5-fold (0.19 log units) below the measured number; the measured number falls inside the stated range.
By their numbers in this assay, from the lowest: compounds 1, 3 and 2 (each within the scatter of the next).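

On a sulfonamide nitrogen, 3,4-dimethyl-1,2-oxazol-5-yl in place of acetyl gives a 1.1-fold lower number from compound 2 to compound 3 (0.04 log units; within the scatter) in this assay. Among these compounds, this is the first measured pair for this position: a five-membered aromatic ring with 7 heavy atoms replaces a ringless group with 3, and the numbers stay within the scatter of each other. Nothing on hand offers an explanation for this result. Going by these compounds, what remains open is whether this position responds to any group at all, such as a carboxylic acid, a primary amine or a longer alkyl chain.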